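Swapping the cyanophenyl of a sulfonamide ether

The source may hold more compounds than are shown below. What is called first, only, known or untested is meant among the compounds shown, and "the series" means these compounds.

Measured so far:
compound 1 `N#Cc1ccc(Oc2cccc(NS(=O)(=O)c3cccc(C(F)(F)F)c3)c2)cc1` — 2200 nM
compound 2 `N#Cc1ccc(Oc2cccc(NC(=O)Nc3cccc(F)c3)c2)cc1` — 3300 nM
compound 3 `N#Cc1ccc(Oc2cccc(NS(=O)(=O)c3ccccc3)c2)cc1` — > 15000 nM (a limit)

Compound 1 was tested in a functional assay on PLC5 cells (Homo sapiens) for inhibition, read by MTT assay, with a stated time of 24 h (a higher number here means a weaker inhibitor, a lower number a stronger inhibitor), and gives 2200 nM. Among the two compounds with a plain number, compound 1 has the lowest value; compound 2, with 3300 nM, lies within the scatter of it, so the two cannot be told apart. For compound 3 only a limit is reported, (the limit of > 15000 nM in this assay, at which 1 of the 3 values shown sits), so no exact number exists for it. Going by the values given here, the one measured step, an at least 6.8-fold higher number from compound 1 to compound 3 (0.83 log units; beyond the scatter), concerns the trifluoromethyl side of compound 1.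

Compound 4 `O=c1[nH]c2ccc(Oc3cccc(NS(=O)(=O)c4cccc(C(F)(F)F)c4)c3)cc2[nH]1` differs elsewhere: a group of 10 heavy atoms (7 carbon, 2 nitrogen, 1 oxygen; one five-membered aromatic ring with 2 hetero atoms, one six-membered aromatic ring of carbon only) in place of a group of 8 heavy atoms (7 carbon, 1 nitrogen; one six-membered aromatic ring of carbon only), on an oxygen on an aromatic ring. The trifluoromethyl sulfonamide part of compound 1 is kept unchanged. Among the compounds with values here, no measured step touches the cyanophenyl side, so the only step in this set gives no direct guide. With the potency-bearing sulfonamide half retained, compound 4 is expected to land near compound 1, with the step of a 1.1-fold lower number from compound 1 to compound 4 (0.04 log units; within the scatter) estimated as small and uncertain in direction. The estimate for compound 4 is 2000 nM, within 500 nM to 8000 nM.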

Compound 4, half-maximal inhibitory concentration: 11500 nM
The estimate for compound 4 lay 5.8-fold (0.76 log units) below the measured number; measured number above the stated range.
By their numbers in this assay, from the lowest: compounds 1 and 2 (each within the scatter of the next); then compound 4. At a limit, above all of these: compound 3.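

Going by these compounds alone, until now, the only measured step concerned the trifluoromethyl side of compound 1; this result shows that the group on the ether oxygen also counts in this assay as well. Putting the two-ring group with the five-membered aromatic ring in place of 4-cyanophenyl gives a 5.2-fold higher number from compound 1 to compound 4 (0.72 log units; beyond the scatter) and so moves the number beyond the scatter. Keeping the trifluoromethyl sulfonamide half unchanged therefore does not by itself keep the number near that of compound 1, and nothing measured here accounts for this step.

Going by these compounds, it remains open whether the same swap would move the number similarly on the core of compound 2. On these data alone, it is also open whether a single change to the 4-cyanophenyl group, such as a carboxylic acid or an amine in place of the nitrile, would keep the number close to that of compound 1.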